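Swapping a carbamoylphenyl tail for a naphthyl tail

The source may hold more compounds than are shown below. What is called first, only, known or untested is meant among the compounds shown, and "the series" means these compounds.

Measured compounds:
compound 1, `COc1ccc(C(c2ccc(OC)cc2)C2CCN(CCCOc3ccc(C(C)=O)cc3OC)CC2)cc1`, 10 nM
compound 2, `COc1cc(C(C)=O)ccc1OCCCN1CCC(C(O)(c2ccc(F)c(F)c2)c2ccc(F)c(F)c2)CC1`, 2.51 nM
compound 3, `NC(=O)c1ccc(OCCCN2CCC(C(c3ccc(F)cc3)c3ccc(F)cc3)CC2)cc1`, 31.6 nM

All three share a piperidine core carrying two aryl groups and a three-carbon chain ending in an aryl ether. In a functional assay (aorta) with Oryctolagus cuniculus as the target (on this read-out lower numbers stand for tighter binding and higher numbers for weaker binding), compound 3 stands at the highest number of the three: compound 1 gives 10 nM and compound 2 gives 2.51 nM, both beyond the scatter from it.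

Compound 4, `Fc1ccc(C(c2ccc(F)cc2)C2CCN(CCCOc3cccc4ccccc34)CC2)cc1`, is not yet measured. It differs from compound 3 by naphthalen-1-yl in place of 4-carbamoylphenyl on an oxygen on a saturated carbon. Within the data shown here, no measured pair shows this exact change, so the direction must be guessed from the spread among compounds 1 to 3. A modest step toward lower numbers is expected, a 1.8-fold lower number from compound 3 to compound 4 (0.24 log units; within the scatter), though it could fall within scatter. Compound 4 is estimated at 18 nM, between 5 nM and 70 nM.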

Compound 4, dissociation constant: 5.01 nM
Beside the measured number, compound 4's estimate is 3.6-fold (0.56 log units) above it; the range from low to high includes it.
By their numbers in this assay, from the lowest: compounds 2, 4 and 1 (each within the scatter of the next, the first and the last beyond it); then compound 3.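

In this assay, placing naphthalen-1-yl instead of 4-carbamoylphenyl on the oxygen gives a 6.3-fold lower number from compound 3 to compound 4 (0.80 log units; beyond the scatter), with the rest of the molecule unchanged. The swap removes the hydrogen-bond donor and acceptor of the tail and adds a second aromatic ring, so the tail does not need that donor or acceptor to reach the lower number. Nothing measured here accounts for this step.

The compounds shown leave open whether losing the carbamoyl group or gaining the second ring matters more. An unsubstituted phenyl on the same oxygen could separate the two.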